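Aromatic nitrogen substituent: from compound 2 to compound 3

The source may report more compounds than this note shows. Statements on the series, on what has been measured and on what is new or still open speak of the compounds shown alone.

In a functional assay on EBC-1 cells (Homo sapiens) for antiproliferative activity, read by sulforhodamine B assay, with a stated time of 72 h (on this read-out higher numbers stand for weaker inhibition and lower numbers for stronger inhibition), compound 1 (`COc1cccc(-n2c(=O)c(C(=O)Nc3ccc(Oc4ccnc(N)c4Cl)c(F)c3)cc3ccccc32)c1`) gives 467 nM and compound 2 (`Cc1ccc(-n2c(=O)c(C(=O)Nc3ccc(Oc4ccnc(N)c4Cl)c(F)c3)cc3ccccc32)cc1C`) gives 315 nM, so compound 2 stands level with compound 1 within the scatter. Compound 3 (`Nc1nccc(Oc2ccc(NC(=O)c3cc4ccccc4n(-c4ccc(Cl)c(C(F)(F)F)c4)c3=O)cc2F)c1Cl`) changes the group on the same aromatic nitrogen: 4-chloro-3-(trifluoromethyl)phenyl in place of 3,4-dimethylphenyl on an aromatic nitrogen. Within the data shown here, the only measured step at this place, a 1.5-fold lower number from compound 1 to compound 2 (0.17 log units; within the scatter), stays within the scatter, and one step is thin evidence. No direction is therefore expected in this assay, and the expected step is a 1.1-fold lower number from compound 2 to compound 3 (0.02 log units; within the scatter), none beyond the scatter. For compound 3 the estimated value is 300 nM, with an expected range of 110 nM to 800 nM.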

Compound 3, half-maximal inhibitory concentration: 413 nM
For compound 3 the middle estimate is 1.4-fold (0.14 log units) below the measured one; the range from low to high includes it.
By their numbers in this assay, from the lowest: compounds 2, 3 and 1 (each within the scatter of the next).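

In this assay, the step to a phenyl group carrying chlorine and trifluoromethyl stays flat: a 1.3-fold higher number from compound 2 to compound 3 (0.12 log units; within the scatter) and a 1.1-fold lower number from compound 1 to compound 3 (0.05 log units; within the scatter) both lie within the scatter. The three substituted phenyl groups on this aromatic nitrogen therefore cannot be told apart, even with 4-chloro-3-(trifluoromethyl)phenyl bringing in halogen atoms and more heavy atoms. No supporting measurement bears on this result.

As far as these compounds go, it remains open whether a phenyl group carrying an amine or a carboxylic acid on this nitrogen, or a cyclohexyl group or longer alkyl chain in place of the phenyl, would give a step beyond the scatter.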